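The source may hold more compounds than are shown below. What is called first, only, known or untested is meant among the compounds shown, and "the series" means these compounds.

The measured compounds, with their numbers in an assay on cells with melanin-concentrating hormone receptor 1 (Homo sapiens) as the target, read by radioligand binding (on this read-out lower numbers stand for stronger inhibition and higher numbers for weaker inhibition), are:
compound 1, `CCOCC(C)Oc1cccc2ccc(N)nc12`: 1070 nM
compound 2, `CC(C)C(C)Oc1cccc2ccc(N)nc12`: 199 nM
compound 3, `COCC(C)Oc1cccc2ccc(N)nc12`: 606 nM

Compound 1 stands at the highest of the three numbers. Its nearest neighbour is compound 3, reached by a 1.8-fold lower number from compound 1 to compound 3 (0.25 log units; within the scatter), which lies within the scatter; its furthest is compound 2, reached by a 5.4-fold lower number from compound 1 to compound 2 (0.73 log units; beyond the scatter), which lies beyond it.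

Compound 4, `CCCCCOc1cccc2ccc(N)nc12`, has not yet been measured in this assay. It differs from compound 1 in one place: a group of 5 heavy atoms (5 carbon; no ring) in place of a group of 6 heavy atoms (5 carbon, 1 oxygen; no ring), on an oxygen on an aromatic ring.

For the measured compounds named here, two measured steps bear on this change. Going from compound 1 to compound 2 exchanges a chain that holds an oxygen for one without, and the number falls by a 5.4-fold lower number from compound 1 to compound 2 (0.73 log units; beyond the scatter). Going from compound 2 to compound 3 puts an oxygen back into the chain, and the number rises by a 3.0-fold higher number from compound 2 to compound 3 (0.48 log units; beyond the scatter). Both point the same way: a chain without oxygen at this position goes with a lower number. Going by the values given here, no measured step separates a branched chain from a straight one, so the size of that part of the change is unknown. Compound 4 is therefore expected to show a modest lowering, a 3.6-fold lower number from compound 1 to compound 4 (0.55 log units; beyond the scatter), with an estimated value of 300 nM and a range from 120 nM to 800 nM.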

Compound 4, half-maximal inhibitory concentration: 580 nM
Compound 4: middle estimate off by 1.9-fold (0.29 log units), on the low side; the measured number falls inside the stated range.
By their numbers in this assay, from the lowest: compound 2; then compounds 4, 3 and 1 (each within the scatter of the next).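

In this assay the pentyl chain of compound 4, which holds no oxygen, does not separate from the oxygen-bearing chain of compound 1 (a 1.8-fold lower number from compound 1 to compound 4 (0.27 log units; within the scatter)) or from the 1-(methoxymethyl)ethyl group of compound 3 (a 1.0-fold lower number from compound 3 to compound 4 (0.02 log units; within the scatter)). For the compounds shown here, compound 4 therefore goes against the pattern suggested by the earlier compounds: at this position on an oxygen on an aromatic ring, the absence of oxygen from the chain does not by itself go with a lower number. Compound 2 stays apart from compound 4 although neither chain holds an oxygen (a 2.9-fold higher number from compound 2 to compound 4 (0.46 log units; beyond the scatter)), which shows that two all-carbon groups can differ beyond the scatter and that the low number of compound 2 goes with 1,2-dimethylpropyl rather than with all-carbon chains in general.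

The compounds shown leave open whether this difference follows from the branching of 1,2-dimethylpropyl or from its particular shape, and how a longer chain, a cyclohexyl ring or a terminal amine would fare on the same oxygen. No measurement offered here accounts for the differences among these four compounds.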